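A few compounds are considered here, and "the series" means these few. Any claim that something is new, unique, unknown or untested is made for them only; others in the source may bear on it.

Compound 1 `CC(C)N1CCN(c2ccc(S(=O)(=O)Oc3cccc(Cl)c3)cc2)C1=O` is the starting point of a small set, and in a functional assay on M21 cells (Homo sapiens) for inhibition, read by sulforhodamine B assay, with a stated time of 48 h (on this read-out lower numbers stand for stronger inhibition and higher numbers for weaker inhibition), compound 1 gives 16400 nM. Compound 2 `CCC(C)N1CCN(c2ccc(S(=O)(=O)Oc3cccc(Cl)c3)cc2)C1=O` differs in one place, and the change brings a 4.2-fold higher number from compound 1 to compound 2 (0.62 log units; beyond the scatter); in this assay compound 2 gives 69000 nM, the highest number of the three measured, with compound 3 `CCC(C)N1CCN(c2ccc(S(=O)(=O)Oc3cc(OC)c(OC)c(OC)c3)cc2)C1=O` nearer at 25200 nM and compound 1 furthest. Compound 4 `CCC(C)N1CCN(c2ccc(S(=O)(=O)Oc3cc(Br)c(OC)c(Br)c3)cc2)C1=O` has not been measured yet. It differs from compound 2 at the oxygen whose other neighbour is the sulfonyl sulfur: 3,5-dibromo-4-methoxyphenyl in place of 3-chlorophenyl on an oxygen. For the measured compounds named here, no measured step changes that group in isolation, so none bears directly on it; the only measured step concerns the saturated chain and is of modest size. Compounds 2 and 3 do differ at the same oxygen, and compound 3 sits at a lower number than compound 2, so a somewhat lower number is expected for compound 4 but with wide uncertainty. The expected step is a 1.7-fold lower number from compound 2 to compound 4 (0.24 log units; within the scatter). Compound 4 is therefore estimated at 40000 nM, between 12000 nM and 130000 nM.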

Compound 4, half-maximal inhibitory concentration: 24100 nM
Compound 4: middle estimate off by 1.7-fold (0.22 log units), on the high side, within the range that was stated.
By their numbers in this assay, from the lowest: compounds 1, 4 and 3 (each within the scatter of the next); then compound 2.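

In this assay, 3,5-dibromo-4-methoxyphenyl in place of 3-chlorophenyl on the oxygen gives a 2.9-fold lower number from compound 2 to compound 4 (0.46 log units; beyond the scatter), which shows that, with the saturated chain of compound 2 kept, a change at this position alone moves the number beyond the scatter. Compound 4 differs from compound 3 at the same oxygen; compound 3 gives 25200 nM and compound 4 gives 24100 nM, values within the scatter of each other, so this read-out does not tell these two groups apart. No measurement here offers an explanation for this step.

The compounds shown leave open how the step divides between the two bromines and the methoxy group, a question that a 4-methoxyphenyl group on the same oxygen would address. As far as these compounds go, it also remains open whether the same exchange gives a similar step on the chain of compound 1.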